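Replacing a Piperidine Amide with a Small Aminomethyl Amide

The source may hold more compounds than are shown below. What is called first, only, known or untested is meant among the compounds shown, and "the series" means these compounds.

Three compounds share one core, a spiro arrangement carrying a tert-butylbenzoyl group, and differ only in the amide attached through a methylene to the ring nitrogen. Compound 1 `CC(C)(C)c1ccc(C(=O)N2CCC3(CC2)C(=O)N(CC(=O)NCCO)CN3c2ccccc2)cc1` carries a (2-hydroxyethyl)amino group and in an assay on HEK293 cells for displacement of a labelled ligand from NPC1-like intracellular cholesterol transporter 1 (Homo sapiens) (on this read-out lower numbers stand for stronger inhibition and higher numbers for weaker inhibition), compound 1 gives 1000 nM. Compound 2 `COC(=O)CCNC(=O)CN1CN(c2ccccc2)C2(CCN(C(=O)c3ccc(C(C)(C)C)cc3)CC2)C1=O` carries a methyl ester chain; in this assay compound 2 gives "not determined" (no result reported), so no number is available for it. For the measured compounds named here, compound 3 `CC(C)(C)c1ccc(C(=O)N2CCC3(CC2)C(=O)N(CC(=O)N2CCC(CCO)CC2)CN3c2ccccc2)cc1` carries a 4-(2-hydroxyethyl)piperidin-1-yl group, and in this assay compound 3 gives 2600 nM, the higher of the two numbers available; its nearest neighbour is compound 1, and the single measured step, a 2.6-fold higher number from compound 1 to compound 3 (0.41 log units; beyond the scatter), shows that opening the piperidine into a small secondary amide is the direction of stronger inhibition.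

Compound 4 `CC(C)(C)c1ccc(C(=O)N2CCC3(CC2)C(=O)N(CC(=O)NCN)CN3c2ccccc2)cc1` differs from compound 3 by one change: (aminomethyl)amino in place of 4-(2-hydroxyethyl)piperidin-1-yl on a carbonyl carbon. This reverses the kind of change seen in the measured step, from a ring-closed tertiary amide to a short secondary amide. Because a 2.6-fold higher number from compound 1 to compound 3 (0.41 log units; beyond the scatter) went the other way, compound 4 is expected to return to roughly the level of compound 1, an estimated step of a 2.2-fold lower number from compound 3 to compound 4 (0.34 log units; beyond the scatter). For compound 4 the estimated result is 1200 nM, expected to fall between 500 nM and 3000 nM.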

Compound 4, half-maximal inhibitory concentration: 26500 nM
For compound 4 the middle estimate is 22-fold (1.34 log units) below the measured one; measured number above the stated range.
By their numbers in this assay, from the lowest: compound 1; then compound 3; then compound 4.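

Compound 4 shows that a short secondary amide at this position does not by itself bring back the level of compound 1: in this assay, the change from the 4-(2-hydroxyethyl)piperidin-1-yl group to (aminomethyl)amino gives a 10-fold higher number from compound 3 to compound 4 (1.01 log units; beyond the scatter). For the compounds shown here, the comparison with compound 1 locates the sensitivity more exactly, since amino in place of hydroxymethyl on a saturated chain carbon bound to an amide-type nitrogen, a swap within the small side chain, gives a 27-fold higher number from compound 1 to compound 4 (1.42 log units; beyond the scatter), a far larger step than a 2.6-fold higher number from compound 1 to compound 3 (0.41 log units; beyond the scatter), the one produced by the change to the piperidine amide. What the side chain carries therefore matters more here than whether the amide is a small open one or a larger ring, although nothing shown gives a reason for the loss.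

The compounds shown leave open whether the amino group itself sets this weak level or whether its attachment on so short a chain does, a question that a 2-aminoethyl chain on the same amide would help to separate. They also leave open how a carboxylic acid or a methoxy group in place of the hydroxyl of compound 1 would read.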